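A few compounds are considered here, and "the series" means these few. Any claim that something is new, unique, unknown or untested is made for them only; others in the source may bear on it.

Three measured compounds share one core and differ only in the substituent on the phenyl ring attached to the thiazole. Compound 1 `Cc1ccc(C2=NN(c3nc(-c4ccc(F)cc4)cs3)C(c3ccc(F)cc3)C2)s1` carries a fluoro there. In an ADME assay on NIH3T3 cells (Mus musculus) for cytotoxicity, read by XTT assay, with a stated time of 24 h (on this read-out higher numbers stand for weaker inhibition and lower numbers for stronger inhibition), compound 1 gives > 500 ug/mL, which is a limit of the assay rather than a number. Compound 3 `Cc1ccc(C2=NN(c3nc(-c4ccccc4)cs3)C(c3ccc(F)cc3)C2)s1` carries a plain phenyl, and in this assay compound 3 gives > 500 ug/mL, again a limit. Compound 2 `Fc1ccc(C2CC(c3ccc(Cl)s3)=NN2c2nc(-c3ccc(C(F)(F)F)cc3)cs2)cc1` carries a trifluoromethyl, and in this assay compound 2 gives > 500 ug/mL, also a limit. Among the measured compounds shown here, the single step between measured compounds that differ in one place, a step that the two limits leave unreadable from compound 1 to compound 3, cannot be read in size, both ends being limits. All three values sit at the same point, (the limit of > 500 ug/mL in this assay, at which 3 of the 3 values shown sit), so compound 2 stands level with the others and no ordering among them can be drawn.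

Compound 4 `Fc1ccc(C2CC(c3ccc(Cl)s3)=NN2c2nc(-c3ccc(Br)cc3)cs2)cc1` is the unmeasured member, and it differs from compound 2 by bromo in place of trifluoromethyl on an aromatic carbon. For the measured compounds named here, no measured step bears on this kind of change, and the one computed step offers no size. The step from compound 2 to compound 4 is therefore expected to be a number no higher from compound 2 to compound 4 (the limit leaves the size open), that is, none beyond the scatter. Compound 4 is expected to give 500 ug/mL in this assay, within a range from 200 ug/mL to 1000 ug/mL.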

Compound 4, half-maximal inhibitory concentration: > 500 ug/mL
Compound 4: no number, only a limit; the forecaster's own chance of this, stated with the estimate: 80%; the middle value sits exactly at the limit.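

Compound 2 and compound 4 both give only a limit in this assay, not a number, so the change from trifluoromethyl to bromo yields no step that can be read: the limit of > 500 ug/mL in this assay, at which 4 of the 4 values shown sit.

The compounds shown leave open what number any of them would give, and whether changing this group on the phenyl ring alters the read-out at all.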